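The source may report more compounds than this note shows. Statements on the series, on what has been measured and on what is new or still open speak of the compounds shown alone.

In a functional assay on B16-F10 cells (Mus musculus) for antiproliferative activity, read by MTT assay, with a stated time of 48 h (a lower number here means a stronger inhibitor, a higher number a weaker inhibitor), compound 3 `Cc1ccc(NCc2cn(-c3ccccc3)nc2-c2ccc(Br)cc2)cc1` gives 5980 nM, within the scatter of compound 2 `COc1ccc(-c2nn(-c3ccccc3)cc2CNc2ccc(F)cc2)cc1` at 6580 nM. Compound 1 `Fc1ccc(NCc2cn(-c3ccccc3)nc2-c2ccc(Cl)cc2)cc1` gives 2120 nM, beyond the scatter below both. Compound 4 `Fc1ccc(NCc2cn(-c3ccccc3)nc2-c2ccc(Br)cc2)cc1` has fluoro in place of methyl on an aromatic carbon, para to a large group: fluoro in place of methyl on an aromatic carbon. For the measured compounds named here, no measured step covers this swap. The only one, a 3.1-fold higher number from compound 1 to compound 2 (0.49 log units; beyond the scatter), is methoxy in place of chloro at a different place, so it bears only indirectly, as a modest change. Compound 1 carries the (4-fluorophenyl)amino group and gives 2120 nM, but compound 2 carries it too and gives 6580 nM, so the hint is weak. A modest move to a lower number in this assay is expected, a 2.1-fold lower number from compound 3 to compound 4 (0.33 log units; beyond the scatter). Compound 4 is estimated at 2800 nM, with an expected range of 1300 nM to 6000 nM.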

Compound 4, half-maximal inhibitory concentration: 4180 nM
The estimate for compound 4 lay 1.5-fold (0.17 log units) below the measured number; the range from low to high includes it.
By their numbers in this assay, from the lowest: compounds 1, 4, 3 and 2 (each within the scatter of the next, the first and the last beyond it).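

At this aromatic carbon, para to a large group, fluoro in place of methyl gives a 1.4-fold lower number from compound 3 to compound 4 (0.16 log units; within the scatter) in this assay, so this swap does not separate from the scatter. With the (4-fluorophenyl)amino group held constant, bromo in place of methoxy gives a 1.6-fold lower number from compound 2 to compound 4 (0.20 log units; within the scatter), and bromo in place of chloro gives a 2.0-fold higher number from compound 1 to compound 4 (0.29 log units; within the scatter). Compound 4 therefore lies within the scatter of both compound 1 and compound 2, although those two differ beyond it.

Nothing measured here explains these numbers. Going by these compounds, whether an amine or a carboxylic acid at this carbon would give a step beyond the scatter remains open.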